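Swapping the ester end group on the shared core

The compounds below may be only part of what the source reports. "The series", "measured", "known", "first", "only" and "open" are said of these compounds alone.

In a functional assay on A549 cells (Homo sapiens) for inhibition, read by MTT assay, with a stated time of 72 h (a higher number here means a weaker inhibitor of growth, a lower number a stronger inhibitor of growth), compound 1 `CC(C)(C)OC(=O)/C=C/C1=CC[C@H]2C(C)(C)CCC[C@]2(C)[C@H]1C=O` gives 29000 nM, and compound 2 `COC(=O)/C=C/C=C/C1=CC[C@H]2C(C)(C)CCC[C@]2(C)[C@H]1C=O` gives 29000 nM. Going by the values given here, compound 2 therefore stands level with compound 1, its only measured neighbour.

The next member is compound 3 `C#CCCCOC(=O)/C=C/C1=CC[C@H]2C(C)(C)CCC[C@]2(C)[C@H]1C=O`. The change is ((pent-4-yn-1-yl)oxy)carbonyl in place of 2-(methoxycarbonyl)ethenyl on a double-bonded chain carbon bound to a double-bonded chain carbon, which puts ((pent-4-yn-1-yl)oxy)carbonyl in place of 2-(methoxycarbonyl)ethenyl on a double-bonded chain carbon bound to a double-bonded chain carbon.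

Among the compounds with values here, one measured step bears on this change, as it alters the group at the same place: no change at the digits printed from compound 1 to compound 2 (within the scatter). That single step is a thin basis, and the new group has a triple bond not seen in either measured compound. No step beyond the scatter is therefore expected in this assay. The expected change is a 1.1-fold lower number from compound 2 to compound 3 (0.05 log units; within the scatter). For compound 3 the estimate is 26000 nM, with an expected range of 11000 nM to 60000 nM.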

Compound 3, concentration for 50% growth inhibition: 30000 nM
Estimate against measurement, compound 3: 1.2-fold (0.06 log units) below, within the range that was stated.
By their numbers in this assay, from the lowest: compounds 1, 2 and 3 (each within the scatter of the next).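

Replacing the end group with ((pent-4-yn-1-yl)oxy)carbonyl, which brings a triple bond into the series, leaves the read-out in this assay unmoved (a 1.0-fold higher number from compound 2 to compound 3 (0.01 log units; within the scatter)). With pent-4-yn-1-yl in place of tert-butyl on an oxygen next to a carbonyl group, the ester alkyl group alone is exchanged, and this step also stays within the scatter (a 1.0-fold higher number from compound 1 to compound 3 (0.01 log units; within the scatter)). Across compounds 1, 2 and 3, this place has so far accepted each of the three end groups without a step beyond the scatter, and nothing measured here explains why.

From the compounds shown here alone, whether a carboxylic acid, an amide or a chain ending in an amine at this place would shift the number remains open. So does the effect of any change to the shared core.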